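The source may report more compounds than this note shows. Statements on the series, on what has been measured and on what is new or still open speak of the compounds shown alone.

Measured compounds:
Compound 1 `CN1CCN(c2cc(Nc3ncc(Br)c(Nc4cccc(CO)c4)n3)cc(S(C)(=O)=O)c2)CC1`: 2.43
Compound 2 `Cc1cnc(Nc2cc(N3CCNCC3)cc(S(C)(=O)=O)c2)nc1Nc1cccc(CO)c1`: 1.09

In a physicochemical assay for lipophilicity, using the shake flask method, in phosphate buffer, measured as octanol-water partition, with a stated time of 5 h, at pH 7.4 (a lower number here means a more polar compound, a higher number a more lipophilic compound), compound 2 gives 1.09, the lowest of the two numbers measured. Going by the values given here, compound 1 gives 2.43, a number that lies beyond the scatter above compound 2; the two compounds differ in more than one place, so no single step connects them and only their two values can be compared. Compound 3 `CC(=O)N1CCN(c2cc(Nc3ncc(C)c(Nc4cccc(CO)c4)n3)cc(S(C)(=O)=O)c2)CC1` has not yet been measured in this assay. It differs from compound 2 by acetyl in place of hydrogen on an amine nitrogen in a ring. Among the compounds with values here, no measured pair carries exactly this change, so the size of the step cannot be read from the data. Within the data shown here, the only other number available, that of compound 1 at 2.43, stands well above compound 2, and the entering acetyl brings three heavy atoms with one hydrogen-bond acceptor and no donor in place of a hydrogen. On that basis compound 3 is expected to move upward from compound 2 by a step beyond the scatter, a number 1.41 log units higher from compound 2 to compound 3 (beyond the scatter). For compound 3 the estimated value in this assay is 2.5, with a range from 1.8 to 3.2.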

Compound 3, distribution coefficient: 1.74
The estimate for compound 3 lay 0.76 log units above the measured number; measured number outside the range, below it.
By their numbers in this assay, from the lowest: compound 2; then compound 3; then compound 1.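

In this assay the change from piperazin-1-yl to 4-acetylpiperazin-1-yl, acetyl in place of hydrogen on an amine nitrogen in a ring, gives a number 0.65 log units higher from compound 2 to compound 3 (beyond the scatter) and so puts a first size on a single change at this position. Until now the measured compounds differed in more than one place, which left any contribution of this ring nitrogen mixed with other differences; here the rest of the structure stays the same, three ring bonds from the ring atom that bears a large group, and the step beyond the scatter belongs to this one change. No measurement available here accounts for the size of this step.

From the compounds shown here alone, what remains open is whether this step is particular to acetyl or would also appear with a longer chain such as propanoyl, or with a carboxylic acid or a primary amine carried on the same ring nitrogen. A single pair also leaves open whether acetyl would give a step of similar size on another core, such as one carrying the bromine of compound 1 in place of the methyl of compound 2.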